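The compounds below may be only part of what the source reports. "The series", "measured", "known", "first", "only" and "open" are said of these compounds alone.

Measured so far in a functional assay, read by spectrophotometry, tested at 100 uM (a higher number here means a weaker inhibitor, a lower number a stronger inhibitor), are these compounds:
- compound 1 `O=C(/C=C/c1cccs1)c1cccc(NC(=O)c2cc(-c3ccncc3)n[nH]2)c1` gives 27600 nM
- compound 2 `O=C(/C=C/c1ccco1)c1cccc(NC(=O)c2cc(-c3ccncc3)n[nH]2)c1` gives 41800 nM

In this assay, among the measured compounds shown here, compound 2 lies within the scatter of compound 1, the only other measured compound, so the two cannot be ranked. Compound 3 `COc1cc(/C=C/C(=O)c2cccc(NC(=O)c3cc(-c4ccncc4)n[nH]3)c2)cc(OC)c1OC` keeps the core of compound 2 and changes one group (3,4,5-trimethoxyphenyl in place of furan-2-yl on a double-bonded chain carbon bound to a double-bonded chain carbon): 3,4,5-trimethoxyphenyl in place of furan-2-yl on a double-bonded chain carbon bound to a double-bonded chain carbon. For the measured compounds named here, only one measured step bears on this change (a 1.5-fold higher number from compound 1 to compound 2 (0.18 log units; within the scatter)). It exchanged thiophen-2-yl for furan-2-yl at that place and stayed within the scatter. Going by the values given here, no measured compound carries a six-membered aromatic ring of carbon only there, so this guide is weak and the range has to stay wide. Among the compounds with values here, with that small step as the only evidence, no change beyond the scatter is expected in this assay and the estimated step is (a 1.4-fold lower number from compound 2 to compound 3 (0.14 log units; within the scatter)). The expected value for compound 3 is 30000 nM (estimated range 9000 nM to 100000 nM).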

Compound 3, half-maximal inhibitory concentration: 54500 nM
Estimate against measurement, compound 3: 1.8-fold (0.26 log units) below, and the stated range covers the measured number.
By their numbers in this assay, from the lowest: compounds 1, 2 and 3 (each within the scatter of the next).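

In this assay, a six-membered aromatic ring of carbon only now stands at this place on a double-bonded chain carbon, and the result is still no step beyond the scatter: 3,4,5-trimethoxyphenyl in place of furan-2-yl gives a 1.3-fold higher number from compound 2 to compound 3 (0.12 log units; within the scatter), and in place of thiophen-2-yl it gives a 2.0-fold higher number from compound 1 to compound 3 (0.30 log units; within the scatter). Among the compounds shown here, the earlier pair compared only two five-membered aromatic rings with 1 hetero atom, whereas these steps span a change in ring type and a rise in the count of heavy atoms, and the three compounds still cannot be ranked. Nothing available here offers an explanation for this outcome.

The compounds shown leave open whether a group with no aromatic ring at this place, such as an amine, a carboxylic acid or a longer alkyl chain, would also stay within the scatter. They also leave open whether an unsubstituted phenyl ring, or a phenyl ring carrying a hydroxyl group, would read like these three, and whether any group at this place can move the number beyond the scatter.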